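Chain length and ring closure in growth inhibition

This account rests on a few compounds, and the source may have more. Where it says the series, first, only, none or still open, it means among the compounds named here.

Measured in a functional assay on HBL-100 cells (Homo sapiens) for antiproliferative activity, read by sulforhodamine B assay, with a stated time of 48 h; a higher number here means a weaker inhibitor of growth, a lower number a stronger inhibitor of growth:
- compound 1 `CCCCC(C#CC(=O)OC)O/C=C/C(=O)OC`: 250 nM
- compound 2 `CCCCCC(C#CC(=O)OC)O/C=C/C(=O)OC`: 1900 nM
- compound 3 `CCCCCCC(C#CC(=O)OC)O/C=C/C(=O)OC`: 2500 nM

Compound 3 gives 2500 nM and shares the weak end of this small set with compound 2, as the data show a 1.3-fold higher number from compound 2 to compound 3 (0.12 log units; within the scatter). The clear gaps run from the shortest chain: a 7.6-fold higher number from compound 1 to compound 2 (0.88 log units; beyond the scatter), and a 10-fold higher number from compound 1 to compound 3 (1.00 log units; beyond the scatter).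

Compound 4 `COC(=O)C#CC(O/C=C/C(=O)OC)C1CCCCC1` keeps the shared core but differs as follows: cyclohexyl in place of hexyl on a saturated chain carbon bound to an oxygen on an unsaturated carbon and a triple-bonded carbon. That is, cyclohexyl in place of hexyl on a saturated chain carbon bound to an oxygen on an unsaturated carbon and a triple-bonded carbon.

For the measured compounds named here, no measured compound carries a ring, so the chain steps offer only indirect guidance. If the ring acts like a shorter chain, the number should move toward compound 1 at 250 nM, but nothing measured tests this. A modest drop in this assay is therefore expected, although a change within the scatter remains possible. The estimated change is a 2.1-fold lower number from compound 3 to compound 4 (0.32 log units; beyond the scatter). Compound 4 is estimated at 1200 nM, with an expected range from 300 nM to 4000 nM.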

Compound 4, concentration for 50% growth inhibition: 2500 nM
Beside the measured number, compound 4's estimate is 2.1-fold (0.32 log units) below it; low and high end bracket the measured number.
By their numbers in this assay, from the lowest: compound 1; then compounds 2, 3 and 4 (each within the scatter of the next).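

Closing the hexyl chain into cyclohexyl, on a saturated chain carbon bound to an oxygen on an unsaturated carbon and a triple-bonded carbon, leaves the reading in this assay unmoved (no change at the digits printed from compound 3 to compound 4 (within the scatter)), so at this size ring and open chain cannot be told apart. The same holds against the pentyl chain (a 1.3-fold higher number from compound 2 to compound 4 (0.12 log units; within the scatter)), while the butyl chain alone stays clearly separate (a 10-fold higher number from compound 1 to compound 4 (1.00 log units; beyond the scatter)), which shows that the ring does not read like that shorter chain. Nothing here gives any measured property that could account for these readings.

On these data alone, the smaller cyclopentyl and cyclopropyl rings remain open, so it is unclear whether a ring with fewer carbons would read like the butyl chain. A flat phenyl ring, or a chain ending in an amine, is equally untested at this position.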